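A few compounds are considered here, and "the series" means these few. Any claim that something is new, unique, unknown or untested is made for them only; others in the source may bear on it.

Measured in a functional assay on HeLa cells (Homo sapiens) for antiproliferative activity, read by MTT assay, with a stated time of 24 h; on this read-out higher numbers stand for weaker inhibition and lower numbers for stronger inhibition:
- compound 1 `Cc1ccc(-c2nn(-c3ccccc3)cc2-c2nc3ccccc3n2S(=O)(=O)c2ccc(C)cc2)cc1`: 480 nM
- compound 2 `Cc1ccc(-c2nn(-c3ccccc3)cc2-c2nc3ccccc3n2S(=O)(=O)c2ccc(F)cc2)cc1`: 3670 nM
- compound 3 `Cc1ccc(-c2nn(-c3ccccc3)cc2-c2nc3ccccc3n2S(=O)(=O)c2ccc(Br)cc2)cc1`: 2340 nM

Compound 3 belongs to the upper pair of these numbers. Its gaps to the other two are a 1.6-fold lower number from compound 2 to compound 3 (0.20 log units; within the scatter) and a 4.9-fold higher number from compound 1 to compound 3 (0.69 log units; beyond the scatter).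

Compound 4 `O=S(=O)(c1ccc(Br)cc1)n1c(-c2cn(-c3ccccc3)nc2-c2ccc(C(F)(F)F)cc2)nc2ccccc21` has trifluoromethyl in place of methyl on an aromatic carbon, 4-methylphenyl to 4-(trifluoromethyl)phenyl (trifluoromethyl in place of methyl on an aromatic carbon). Within the data shown here, no measured step changes this group. The closest in kind are a 7.6-fold higher number from compound 1 to compound 2 (0.88 log units; beyond the scatter) and a 4.9-fold higher number from compound 1 to compound 3 (0.69 log units; beyond the scatter), both modest. Each replaces a methyl on an aromatic carbon elsewhere in the molecule and gives weaker inhibition in this assay, but neither can be carried over directly to this place. Only a slight move towards a higher number is therefore expected, not a step beyond the scatter. The estimated step is a 1.3-fold higher number from compound 3 to compound 4 (0.11 log units; within the scatter). For compound 4 the expected value is 3000 nM, with an estimated range from 1000 nM to 9000 nM.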

Compound 4, half-maximal inhibitory concentration: 1860 nM
For compound 4 the middle estimate is 1.6-fold (0.21 log units) above the measured one, within the range that was stated.
By their numbers in this assay, from the lowest: compound 1; then compounds 4, 3 and 2 (each within the scatter of the next).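

In this assay, among these compounds, trifluoromethyl in place of methyl on the 4-methylphenyl group gives a step within the scatter (a 1.3-fold lower number from compound 3 to compound 4 (0.10 log units; within the scatter)), the first reading at this position, taken with the bromo group kept elsewhere in the molecule. The earlier replacements of a methyl on an aromatic carbon, made at another place, both lay beyond the scatter (a 7.6-fold higher number from compound 1 to compound 2 (0.88 log units; beyond the scatter)) and (a 4.9-fold higher number from compound 1 to compound 3 (0.69 log units; beyond the scatter)), so those steps do not describe this position. No measured evidence bears on the reason for this difference between the two places.

On these data alone, it remains open whether the same change reads alike with methyl rather than bromo at the other place. An amine or a carboxylic acid in place of the methyl on this phenyl group could show whether this position responds beyond the scatter at all.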